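Removal of the amino group from the core of compound 2

The compounds below may be only part of what the source reports. "The series", "measured", "known", "first", "only" and "open" are said of these compounds alone.

Compound 1 `Cc1ncc2c(n1)CCN(C)C2` and compound 2 `CN1CCc2nc(N)ncc2C1` share one core and differ at a single aromatic carbon. In a functional assay on the whole organism for inhibition, with Rattus norvegicus as the target, with stated times of 1 h and 3.5 h, at a dose of 100 mg/kg by the oral route (a lower number here means less inhibition, a higher number more inhibition at the dose given (going by the name of the read-out)), compound 1 gives 45%. For compound 2 this assay reports only a limit, < 5%, so compound 2 stands at the limit and no number is known for it (the limit of < 5% in this assay, at which 1 of the 2 values shown sits). The measured step of a number at least 40 percentage points lower from compound 1 to compound 2 (beyond the scatter) is the only one in the set and shows that the group on this carbon matters strongly.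

Compound 3 `CN1CCc2ncncc2C1` differs from compound 2 by hydrogen in place of amino on an aromatic carbon. The change runs in neither direction of the measured step: the hydrogen is not the methyl of compound 1 and not the amino of compound 2. A rise from the limit is expected, estimated as a number at least 15 percentage points higher from compound 2 to compound 3 (beyond the scatter), but its size is uncertain. Compound 3 is therefore expected to give 20%, within 5% to 45%.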

Compound 3, a percentage reported as inhibition, in the whole organism at one dose (the size of the read-out at that dose, not a potency): 50%
Beside the measured number, compound 3's estimate is 30 percentage points below it; measured number outside the range, above it.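

In this assay, hydrogen in place of amino on the aromatic carbon between two ring nitrogen atoms gives a number at least 45 percentage points higher from compound 2 to compound 3 (beyond the scatter), so the low end of the series belongs to the amino compound and not to the loss of methyl alone. Hydrogen in place of methyl gives a number 5 percentage points higher from compound 1 to compound 3 (within the scatter), so methyl and hydrogen cannot be told apart here, and this read-out does not need a carbon substituent at this position. The value of compound 2 is a limit and not a number: the limit of < 5% in this assay, at which 1 of the 3 values shown sits.

The compounds shown leave open whether the drop is specific to amino or also extends to dimethylamino, hydroxyl or methoxy on this carbon. On these data alone, it is also open whether a longer chain such as ethyl stays level with compound 1 and compound 3.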